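The source may report more compounds than this note shows. Statements on the series, on what has been measured and on what is new or still open speak of the compounds shown alone.

Measured compounds:
compound 1 `CC(=O)c1ccc(/C=C2\CCCN=C2c2cccnc2)cc1`, 4490 nM
compound 2 `CC(C)(C)C(=O)Oc1ccccc1/C=C1\CCCN=C1c1cccnc1`, 1440 nM
compound 3 `COc1cccc(/C=C2\CCCN=C2c2cccnc2)c1`, 1180 nM

In an assay on membranes from brain for displacement of a labelled ligand from Neuronal acetylcholine receptor; alpha4/beta2 (Rattus norvegicus), with a stated time of 3 h (on this read-out higher numbers stand for weaker inhibition and lower numbers for stronger inhibition), compound 1 gives the highest of the three numbers; compound 2 and compound 3 both sit lower, each by a gap beyond the usual scatter. Compound 4 `Clc1ccc(/C=C2\CCCN=C2c2cccnc2)cc1` is not yet measured in this assay. It differs from compound 1 in one place: chloro in place of acetyl on an aromatic carbon. The place is an aromatic carbon of a six-membered aromatic ring of carbon only, para to a large group. Going by the values given here, no step between measured compounds tracks this change, so the expectation rests on the spread alone. A modest step toward a lower number is expected, of the order of a 2.2-fold lower number from compound 1 to compound 4 (0.35 log units; beyond the scatter), though it may fall within the scatter. Compound 4 is estimated at 2000 nM, within 600 nM to 6000 nM.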

Compound 4, inhibition constant: 970 nM
Beside the measured number, compound 4's estimate is 2.1-fold (0.31 log units) above it; the range from low to high includes it.
By their numbers in this assay, from the lowest: compounds 4, 3 and 2 (each within the scatter of the next); then compound 1.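

In this assay, going by these compounds alone, chloro in place of acetyl on this aromatic carbon, para to a large group, gives a 4.6-fold lower number from compound 1 to compound 4 (0.67 log units; beyond the scatter) and provides the first step that tracks a single change. The substituent at this place alone therefore moves the number beyond the scatter, with the shared core unchanged. No available measurement explains this step.

From the compounds shown here alone, it remains open whether the step reflects the arrival of chloro or the departure of acetyl. Fluoro, methyl, an amine or a carboxylic acid on this carbon would help separate the two.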